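Cytotoxicity notes on a thiazole amide series

The source may hold more compounds than are shown below. What is called first, only, known or untested is meant among the compounds shown, and "the series" means these compounds.

Measured so far:
compound 1 `O=C(Nc1ncc(Cc2ccc(F)cc2)s1)c1ccc(Br)cc1` — > 50000 nM
compound 2 `O=C(Nc1ncc(C(Oc2ccc3cc(Br)ccc3c2)c2ccc(Cl)cc2)s1)c1cccs1` — "not toxic" (no number reported)
compound 3 `COc1ccc(COC(c2ccccc2)c2cnc(NC(=O)c3cccs3)s2)cc1` — "not toxic" (no number reported)

In an ADME assay on HepG2 2.2.15 cells (Homo sapiens) for cytotoxicity (a lower number here means that less compound is tolerated, a higher number that more compound is tolerated), compound 1 reaches only a limit of the assay, > 50000 nM, and no number. Compound 2 carries no number in this assay either, only the entry "not toxic" (no number reported). Compound 3 likewise shows "not toxic" (no number reported) in this assay. So compound 2 cannot be ranked: one companion sits at a limit, the other has no number, and no two-compound step is measured anywhere in the set. What can be said is summarised in the limit of > 50000 nM in this assay, at which 1 of the 3 values shown sits.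

Compound 4 `O=C(Nc1ncc(C(Oc2ccc3cc(Br)ccc3c2)c2ccc(Cl)cc2)s1)c1ccc(Cl)nc1` is not yet measured. It differs from compound 2 in one place: 6-chloropyridin-3-yl in place of thiophen-2-yl on a carbonyl carbon. The rest of the structure, including the bromonaphthyl ether and the chlorophenyl, is kept.

Among the compounds with values here, no measured step supports a direction here. Given that compound 2 is recorded as "not toxic" (no number reported) in this assay, no step beyond the scatter is expected for compound 4 in this assay. For compound 4 an entry without a single number is the likelier read-out. Compound 4 is therefore estimated at 50000 nM in this assay, with a range of 20000 nM to 100000 nM.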

Compound 4, half-maximal cytotoxic concentration: "not toxic" (no number reported)
No number was reported for compound 4; there is nothing to compare the estimate with.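

Compound 2 and compound 4 both stand in this assay as "not toxic" without a number; no step can be read between them. The compounds shown leave open at what concentration any of them becomes cytotoxic, and the only figure given is a limit: the limit of > 50000 nM in this assay, at which 1 of the 4 values shown sits.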